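Replacing 4-methylphenyl on compound 3

The source may hold more compounds than are shown below. What is called first, only, known or untested is meant among the compounds shown, and "the series" means these compounds.

Compound 1 `COc1cc(F)ccc1Nc1nn(C2CCCCO2)c2cc(-c3c(C)noc3C)ccc12` gives 8500 nM
Compound 2 `COc1ccc(CN2CC(c3ccc(O)cc3)c3cnc(-c4c(C)noc4C)nc32)cc1` gives "not determined" (no result reported)
Compound 3 `CNc1cc(-c2ccc3cnn(Cc4ccc(C)cc4)c3c2)cn(C)c1=O` gives 3280 nM

All three compounds were taken through a functional assay on MV4-11 cells (Homo sapiens) for antiproliferative activity, read by luminescence and CellTiter-Glo, with a stated time of 72 h; a higher number here means a weaker inhibitor, a lower number a stronger inhibitor (the values above come from it). Only two of them returned a number. Compound 3 holds the lower of those two, and compound 1 stands above it by a gap that lies beyond the usual scatter. Compound 2 offers no comparison, and the two numbers that exist belong to compounds with different structures.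

The next compound is compound 4 `CNc1cc(-c2ccc3cnn(Cc4ccc(OC)c(F)c4)c3c2)cn(C)c1=O`, which keeps the rest of compound 3 and changes one group: 3-fluoro-4-methoxyphenyl in place of 4-methylphenyl on a saturated chain carbon bound to an aromatic nitrogen. Within the data shown here, no measured pair here shows what a change of this kind does, so any expectation is loose and has to start from compound 3 at 3280 nM (its own value). A small shift towards a lower number seems the likeliest outcome, though not one that clears the scatter. The expected change in this assay is a 1.5-fold lower number from compound 3 to compound 4 (0.17 log units; within the scatter) (an estimate only). The estimated value for compound 4 is 2200 nM (expected range 700 nM to 6500 nM).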

Compound 4, half-maximal inhibitory concentration: 4980 nM
The estimate for compound 4 lay 2.3-fold (0.35 log units) below the measured number; measured number inside the range.
By their numbers in this assay, from the lowest: compounds 3, 4 and 1 (each within the scatter of the next, the first and the last beyond it).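

In this assay, among these compounds, the step at this position, on a saturated chain carbon bound to an aromatic nitrogen, is a 1.5-fold higher number from compound 3 to compound 4 (0.18 log units; within the scatter), which makes this the first comparison between compounds that differ in one place. It shows that 3-fluoro-4-methoxyphenyl, with 9 heavy atoms and 1 hydrogen-bond acceptor, can stand in place of 4-methylphenyl, with 7 heavy atoms and 0 hydrogen-bond acceptors, while the two compounds remain within the scatter of each other and cannot be told apart in this read-out. Nothing in hand accounts for this outcome or links it to any feature of either group.

The compounds shown do not separate the fluorine from the methoxy part of the entering group, so neither can be judged on its own at this position. Going by these compounds, it also remains open whether a group of a different kind on the same chain carbon, such as an amine, a carboxylic acid or a longer chain in place of the ring, would produce a step beyond the scatter.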